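Swapping Isopropyl for Cyano: A Small Shift Expected

The source may report more compounds than this note shows. Statements on the series, on what has been measured and on what is new or still open speak of the compounds shown alone.

Compound 2 `CC(C)c1ccccc1-c1cccc(CNc2ccc(OCC(=O)O)c(F)c2)c1` holds the higher of the two numbers recorded so far in a functional assay on CHO cells for agonist activity at Free fatty acid receptor 1 (Homo sapiens), read by FLIPR and calcium flux (a higher number here means that more compound is needed for the effect, a lower number that less compound is needed), giving 86.2 nM, while compound 1 `O=C(O)COc1ccc(NCc2cccc(-c3ccccc3)c2)cc1F` gives 58.5 nM; the step of a 1.5-fold higher number from compound 1 to compound 2 (0.17 log units; within the scatter) is within the scatter. Compound 3 `N#Cc1ccccc1-c1cccc(CNc2ccc(OCC(=O)O)c(F)c2)c1` differs from compound 2 by cyano in place of isopropyl on an aromatic carbon. Among the compounds with values here, only that single isopropyl step bears on this change, and it altered the number by little. With nothing measured for cyano, compound 3 is expected to stay close to compound 2, estimated at 65 nM with a range of 25 nM to 170 nM, a step of a 1.3-fold lower number from compound 2 to compound 3 (0.12 log units; within the scatter) expected to remain within the scatter.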

Compound 3, half-maximal effective concentration in the Free fatty acid receptor 1 assay: 729 nM
Estimate against measurement, compound 3: 11-fold (1.05 log units) below; measured number above the stated range.
By their numbers in the Free fatty acid receptor 1 assay, from the lowest: compounds 1 and 2 (each within the scatter of the next); then compound 3.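

Isopropyl at this aromatic carbon left the Free fatty acid receptor 1 assay within the scatter of hydrogen, with a 1.5-fold higher number from compound 1 to compound 2 (0.17 log units; within the scatter), but cyano does not: compound 3 gives 729 nM, with an 8.5-fold higher number from compound 2 to compound 3 (0.93 log units; beyond the scatter) and a 12-fold higher number from compound 1 to compound 3 (1.10 log units; beyond the scatter). The position therefore does respond to the group placed there, and more compound is needed with cyano than with either hydrogen or isopropyl. No available evidence accounts for this result.

In a physicochemical assay for lipophilicity, read by HPLC, in phosphate buffer, measured as octanol-water partition, at pH 7.4, tested at 100 uM (on this read-out higher numbers stand for higher lipophilicity and lower numbers for lower lipophilicity), compound 2 gives 3.45, while compound 3 gives "not determined" (no result reported), so the step from compound 2 cannot be read. As far as these compounds go, whether a methoxy group or a chlorine atom here would stay near compound 2 or compound 3 remains open.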